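Chain extension on the methoxyphenyl side arm

The source may report more compounds than this note shows. Statements on the series, on what has been measured and on what is new or still open speak of the compounds shown alone.

The series shares one core. Compound 1 `Nc1nc(Cc2cccc(C(F)(F)F)c2)nc2cn(-c3ccccc3)nc12` carries a trifluoromethyl-bearing benzyl side arm, compound 2 `Nc1nc(Cc2cccc(Cl)c2)nc2cn(-c3ccccc3)nc12` a chloro-bearing one, and compound 3 `COc1ccc(CCc2nc(N)c3nn(-c4ccccc4)cc3n2)cc1` a 4-methoxyphenyl on a two-carbon chain. In an assay on CHO cells for displacement of a labelled ligand from adenosine receptor A3 (Homo sapiens), read by scintillation counting, tested at 1 uM (a higher number here means more inhibition at the concentration tested (going by the name of the read-out), a lower number less inhibition), compound 1 gives 41% and compound 2 gives 42%; the step of a number 1 percentage points higher from compound 1 to compound 2 (within the scatter) stays within the scatter. Compound 3 gives 22%, the lowest of the three numbers, with compound 1 nearest and compound 2 furthest, both beyond the scatter.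

Compound 4 `COc1ccc(CCCc2nc(N)c3nn(-c4ccccc4)cc3n2)cc1` differs from compound 3 by 4-methoxybenzyl in place of 4-methoxyphenyl on a saturated chain carbon, two bonds along the chain from an aromatic carbon. Among the measured compounds shown here, no measured step concerns a change in chain length; the only recorded step, a number 1 percentage points higher from compound 1 to compound 2 (within the scatter), swaps one aromatic substituent for another and lies within the scatter, so it gives no guide to direction or size here. With nothing to suggest movement, the expected step is no change at the digits printed from compound 3 to compound 4 (within the scatter), none beyond the scatter, but the range is kept wide. The estimate for compound 4 in this assay is 22%, running from 5% to 45%.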

Compound 4, a percentage reported as inhibition, at one concentration (the size of the read-out at that concentration, not a potency): 1%
Compound 4: middle estimate off by 21 percentage points, on the high side, and the stated range ends above it.
By their numbers in this assay, from the lowest: compound 4; then compound 3; then compounds 1 and 2 (each within the scatter of the next).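

In this assay the series responds to chain length on the methoxyphenyl side arm: 4-methoxybenzyl in place of 4-methoxyphenyl on a saturated chain carbon, two bonds along the chain from an aromatic carbon, gives a number 21 percentage points lower from compound 3 to compound 4 (beyond the scatter). The earlier step, a number 1 percentage points higher from compound 1 to compound 2 (within the scatter), swapped one aromatic substituent for another, so this is the first step shown to move the number beyond the scatter, with compound 4 at 1%. Nothing at hand explains the drop.

On these data alone, whether a longer chain carrying the same 4-methoxyphenyl would keep the number this low remains open, as does whether the drop depends on the methoxy group. An amine or a carboxylic acid in place of the 4-methoxyphenyl would test whether this position needs an aromatic ring at all.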